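The source may hold more compounds than are shown below. What is called first, only, known or untested is meant among the compounds shown, and "the series" means these compounds.

Measured compounds:
compound 1, `CCn1c(CN2CCN(C(=O)C3CC3)CC2)nc2ccccc21`, 20.8%
compound 2, `COc1ccc(C(=O)N2CCN(Cc3nc4ccccc4n3Cc3cccc(C)c3)CC2)cc1`, 55.5%

In an assay on isolated protein for inhibition of aldehyde dehydrogenase 1A1 (Homo sapiens), read by spectrophotometry, tested at 10 uM (a lower number here means less inhibition, a higher number more inhibition at the concentration tested (going by the name of the read-out)), compound 1 gives 20.8%, the lowest of the two numbers. Compound 2 stands higher, by a gap beyond the usual scatter, but it differs from compound 1 in more than one place, so no single change can be credited with that gap.

Compound 3, `O=C(C1CC1)N1CCN(Cc2nc3ccccc3n2CC2CCCC2)CC1`, has not been tested in this assay. Within the data shown here, its single change from compound 1 is cyclopentyl in place of methyl on a saturated chain carbon bound to an aromatic nitrogen; the same difference, cut one bond further out, reads ethyl to cyclopentylmethyl. No step between two measured compounds follows this kind of change, so the expected size rests only on the two numbers shown. The comparison suggests a modest rise, though it is uncertain. Compound 3 is estimated at 35%, with a range from 15% to 60%, which would mean an expected step of a number 14.2 percentage points higher from compound 1 to compound 3 (beyond the scatter).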

Compound 3, a percentage reported as inhibition, at one concentration (the size of the read-out at that concentration, not a potency): 44.5%
Compound 3: middle estimate off by 9.5 percentage points, on the low side; measured number inside the range.
By their numbers in this assay, from the lowest: compound 1; then compound 3; then compound 2.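

In this assay, putting cyclopentyl in place of methyl on a saturated chain carbon bound to an aromatic nitrogen gives a number 23.7 percentage points higher from compound 1 to compound 3 (beyond the scatter). Among these compounds, this is the first step in the set that changes only one place, so this rise can be tied to that single swap, which the gap involving compound 2 did not allow. It also shows that this position accepts a much larger all-carbon ring without losing inhibition, while no measurement at hand speaks to why the number rises.

From the compounds shown here alone, what stays open is whether the ring matters or simply the added carbons, a question that an open pentyl chain at this place would address. Also open, going by these compounds, is how an amine or a carboxylic acid on this chain would read in the same test.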